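The source may report more compounds than this note shows. Statements on the series, on what has been measured and on what is new or still open speak of the compounds shown alone.

In a functional assay on T47D cells (Homo sapiens) for cytotoxicity, read by sulforhodamine B assay, with a stated time of 48 h, tested at 0.01 uM (on this read-out higher numbers stand for a weaker effect at the one concentration tested and lower numbers for a stronger effect), compound 2 `COc1cc(-c2cc(/C=C/C(=O)c3ccc(Cl)c(Cl)c3)[nH]n2)cc(OC)c1OC` gives 90%. Compound 1 `COc1cc(-c2cc(/C=C/C(=O)c3ccc(N)cc3)[nH]n2)cc(OC)c1OC` gives 83% and compound 3 `COc1ccc(-c2cc(/C=C/C(=O)c3ccc(N)cc3)[nH]n2)cc1OC` gives 85%; the step of a number 7 percentage points higher from compound 1 to compound 2 (within the scatter) and the step of a number 2 percentage points higher from compound 1 to compound 3 (within the scatter) both lie within the scatter, so the three numbers cannot be told apart. Compound 4 `COc1ccc(C(=O)/C=C/c2cc(-c3cc(OC)c(OC)c(OC)c3)n[nH]2)cc1` differs from compound 2 by 4-methoxyphenyl in place of 3,4-dichlorophenyl on a carbonyl carbon. Going by the values given here, the one measured step that touches the same carbonyl carbon is a number 7 percentage points higher from compound 1 to compound 2 (within the scatter), which stayed within the scatter when one aryl group replaced another there, and the change on an aromatic carbon in a number 2 percentage points higher from compound 1 to compound 3 (within the scatter) was likewise flat. The account therefore expects no step beyond the scatter, a number 4 percentage points lower from compound 2 to compound 4 (within the scatter). Compound 4 is estimated at 86%, with a range from 74% to 98%.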

Compound 4, a percentage reported as activity, at one concentration (the size of the read-out at that concentration, not a potency): 96%
Compound 4: the middle estimate sits 10 percentage points below what was measured, and the stated range covers the measured number.
By their numbers in this assay, from the lowest: compounds 1, 3, 2 and 4 (each within the scatter of the next, the first and the last beyond it).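

In this assay, the exchange of aryl groups on the carbonyl carbon stays flat for one pair, a number 6 percentage points higher from compound 2 to compound 4 (within the scatter), but the same position now gives its first step beyond the scatter, a number 13 percentage points higher from compound 1 to compound 4 (beyond the scatter), with methoxy in place of amino on an aromatic carbon. The position is therefore not wholly indifferent, although this step is modest and points to a weaker effect for compound 4 at the one concentration tested. Nothing at hand gives a reason for this step. Going by these compounds, whether a hydroxy or dimethylamino group would keep the lower number of compound 1 stays open.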